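Pyridinyl in place of trifluoromethyl on the fused ring

The source may report more compounds than this note shows. Statements on the series, on what has been measured and on what is new or still open speak of the compounds shown alone.

Compound 1 `C[C@H](Oc1ccc(S(C)(=O)=O)cc1C(=O)N1Cc2ccc(C(F)(F)F)cc2C1)C(F)(F)F` was examined in an assay on CHO cells for inhibition of sodium- and chloride-dependent glycine transporter 1 (Homo sapiens), read by scintillation counting (a lower number here means that less compound is needed, a higher number that more compound is needed for the effect), where compound 1 gives 21 nM. Among the three measured compounds this is the lowest number: compound 2 `C[C@H](Oc1ccc(S(C)(=O)=O)cc1C(=O)N1Cc2cc(C(F)(F)F)cnc2C1)C(F)(F)F` gives 50 nM and compound 3 `C[C@H](Oc1ccc(S(C)(=O)=O)cc1C(=O)N1Cc2cnc(C(F)(F)F)cc2C1)C(F)(F)F` gives 132 nM, and both of these steps up from compound 1 lie beyond the scatter. Compound 4 `C[C@H](Oc1ccc(S(C)(=O)=O)cc1C(=O)N1Cc2ccc(-c3ccncc3)cc2C1)C(F)(F)F` differs from compound 1 in a single place: pyridin-4-yl in place of trifluoromethyl on an aromatic carbon. Going by the values given here, no measured pair shows the effect of such an exchange, so the direction of the step is open. A moderate rise in the number, somewhat beyond the scatter, is expected for compound 4, which would mean a 2.4-fold higher number from compound 1 to compound 4 (0.38 log units; beyond the scatter). Compound 4 is therefore estimated at 50 nM, with a plausible range from 12 nM to 200 nM.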

Compound 4, half-maximal effective concentration: 17 nM
Estimate against measurement, compound 4: 2.9-fold (0.47 log units) above; the range from low to high includes it.
By their numbers in this assay, from the lowest: compounds 4 and 1 (each within the scatter of the next); then compound 2; then compound 3.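

In this assay, the step from trifluoromethyl to pyridin-4-yl on this aromatic carbon gives a 1.2-fold lower number from compound 1 to compound 4 (0.09 log units; within the scatter). The earlier compounds shown here all carried trifluoromethyl on the fused ring system, whereas this pair shows that an aromatic ring with a hydrogen-bond acceptor can stand here with the number held within the scatter. Nothing available explains this result.

Whether the ring nitrogen of pyridin-4-yl matters remains open, as phenyl and pyridin-3-yl are absent from the compounds shown. Also open, going by these compounds, is how a saturated amine such as morpholine would fare on this carbon.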